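The source may report more compounds than this note shows. Statements on the series, on what has been measured and on what is new or still open speak of the compounds shown alone.

Compound 1 `Cc1ccccc1NC(=O)Nc1cccc(CNc2ncnc3ccccc23)c1` is one of three close relatives tested in a functional assay on HepG2 cells (Homo sapiens) for antiproliferative activity, read by MTT assay; on this read-out lower numbers stand for stronger inhibition and higher numbers for weaker inhibition. In this assay compound 1 gives > 50000 nM, which is a limit of the assay rather than a number. Compound 2 `Cc1cccc(NC(=O)Nc2cccc(CNc3ncnc4ccccc34)c2)c1` carries 3-methylphenyl in place of 2-methylphenyl on the amide-type nitrogen. In this assay compound 2 gives > 50000 nM, again a limit. Compound 3 `O=C(Nc1ccc(F)cc1)Nc1cccc(CNc2ncnc3ccccc23)c1` carries 4-fluorophenyl at that nitrogen instead, and in this assay compound 3 gives 41500 nM. Because two of the three values sit at the same limit (the limit of > 50000 nM in this assay, at which 2 of the 3 values shown sit), the steps among them are hard to read: a step that the two limits leave unreadable from compound 1 to compound 2, while an at least 1.2-fold lower number from compound 1 to compound 3 (0.08 log units; that floor lies within the scatter) and an at least 1.2-fold lower number from compound 2 to compound 3 (0.08 log units; that floor lies within the scatter). Compound 4 `O=C(Nc1cccc(CNc2ncnc3ccccc23)c1)Nc1ccccc1Cl` has not yet been measured. It differs from compound 1 by chloro in place of methyl on an aromatic carbon. Every change so far on this ring, swapping or moving a single small group, left the number at or near the limit, and a change of similar scale is expected to do the same here. For compound 4 the estimate is 50000 nM, with a range from 20000 nM to 150000 nM. This estimate means a step of a number no higher from compound 1 to compound 4 (the limit leaves the size open), with a good chance that only a limit is reported.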

Compound 4, half-maximal inhibitory concentration: > 50000 nM
Compound 4: only a limit was reported (the forecaster's own chance of this, stated with the estimate: 70%); the middle value sits exactly at the limit.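

With chloro in place of methyl on the aromatic carbon ortho to a large group, the number stays at the limit, so this second small group at the same place gives no readable gain in this assay. Going by these compounds alone, the steps from compound 1 and from compound 2 to compound 4 cannot be read, because both ends of each step are limits: the limit of > 50000 nM in this assay, at which 3 of the 4 values shown sit. The only readable comparison is with the 4-fluorophenyl group of compound 3, which gives an at least 1.2-fold higher number from compound 3 to compound 4 (0.08 log units; that floor lies within the scatter), so even this step does not clearly separate the 2-chlorophenyl group from the 4-fluorophenyl group.

Going by these compounds, how far compound 1, compound 2 and compound 4 really lie from one another past the limit stays open, and so does whether methyl and chloro differ at all at this place. Also open, on these data alone, is whether a different kind of group on this ring, such as an amine, a carboxylic acid or a longer chain, would bring the number well clear of the limit.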